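The source may hold more compounds than are shown below. What is called first, only, known or untested is meant among the compounds shown, and "the series" means these compounds.

Measured compounds:
compound 1 `CCc1ccccc1-c1cc(C(=O)N[C@@H](CCN2CCCCC2)CC(=O)NC2CCC2)nn1C1CCCC1`: 76.5%
compound 2 `O=C(C[C@H](CCN1CCCCC1)NC(=O)c1cc(-c2cccc[n+]2[O-])n(C2CCCC2)n1)NC1CCC1`: "nd" (no result reported)
compound 3 `O=C(C[C@H](CCc1ccc(F)cc1)NC(=O)c1cc(-c2ccccc2C(F)(F)F)n(C2CCCC2)n1)NC1CCC1`: "nd" (no result reported)

The account follows the step from compound 3 to compound 4. In an ADME assay on microsomes from liver (Rattus norvegicus, strain Sprague-Dawley) for metabolic stability, read by LC-MS, using NADPH, with a stated time of 30 min, tested at 1 uM (a lower number here means that less of the compound is left, a higher number that more of the compound is left), compound 3 gives "nd" (no result reported), so no number is known for it, and compound 2 likewise gives "nd" (no result reported) in this assay. The only figure available is for compound 1, which in this assay gives 76.5%. Compound 4 `CC(C)CN(C)CC[C@@H](CC(=O)NC1CCC1)NC(=O)c1cc(-c2ccccc2C(F)(F)F)n(C2CCCC2)n1` differs from compound 3 in one place: isobutyl(methyl)amino in place of 4-fluorophenyl on a saturated chain carbon, three bonds along the chain from an amide-type nitrogen. For the measured compounds named here, no step between measured compounds is known for this series, and compound 3 itself offers no number to set a direction against. Compound 1 carries a basic amine on the same chain and is largely left after the incubation, and compound 4 likewise carries an amine on that chain, so a comparable outcome is expected rather than a marked shift in either direction. On that basis compound 4 is expected to give about 65% in this assay, within a range from 35% to 90%.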

Compound 4, percent of the compound remaining: 63.6%
For compound 4 the middle estimate is 1.4 percentage points above the measured one, and the stated range covers the measured number.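

In this assay, for the compounds shown here, compound 3 gives "nd" (no result reported) and compound 4 gives 63.6%, so no step between the two can be read. The compounds shown leave open how isobutyl(methyl)amino in place of 4-fluorophenyl changes the percent of compound remaining. No evidence on hand bears on this result.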